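Removing the pyridin-2-yl group from compound 2

The compounds below may be only part of what the source reports. "The series", "measured", "known", "first", "only" and "open" are said of these compounds alone.

Among the compounds with values here, in a functional assay on COLO 205 cells (Homo sapiens) for antiproliferative activity, read by sulforhodamine B assay, with a stated time of 72 h (on this read-out higher numbers stand for weaker inhibition and lower numbers for stronger inhibition), compound 1 `Cc1cc(C)nc(NS(=O)(=O)c2ccc(Nc3nncc4ccccc34)cc2)n1` gives 7.9 nM and compound 2 `O=S(=O)(Nc1ccccn1)c1ccc(Nc2nncc3ccccc23)cc1` gives 44 nM, the higher of the two numbers so far. Compound 3 `NS(=O)(=O)c1ccc(Nc2nncc3ccccc23)cc1` has hydrogen in place of pyridin-2-yl on a sulfonamide nitrogen. Within the data shown here, one measured step bears on this: a 5.6-fold higher number from compound 1 to compound 2 (0.75 log units; beyond the scatter), a modest change at the same nitrogen and beyond the scatter. A single step is thin guidance, but the substituent now goes entirely, so a somewhat larger rise is expected in this assay. The expected step is a 4.1-fold higher number from compound 2 to compound 3 (0.61 log units; beyond the scatter). For compound 3 the estimated value is 180 nM, with an expected range of 45 nM to 800 nM.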

Compound 3, half-maximal inhibitory concentration: 23 nM
Compound 3: middle estimate off by 7.8-fold (0.89 log units), on the high side; measured number outside the range, below it.
By their numbers in this assay, from the lowest: compound 1; then compounds 3 and 2 (each within the scatter of the next).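

In this assay the sulfonamide nitrogen does not need pyridin-2-yl, with a 1.9-fold lower number from compound 2 to compound 3 (0.28 log units; within the scatter), a step within the scatter. The 4,6-dimethylpyrimidin-2-yl group differs from hydrogen at this nitrogen, with a 2.9-fold higher number from compound 1 to compound 3 (0.46 log units; beyond the scatter), so of the two substituents only this one separates from hydrogen here. Nothing available explains this difference between the two groups.

From the compounds shown here alone, whether the gain in compound 1 goes with the pyrimidine ring or with its methyl groups remains open. An unsubstituted pyrimidin-2-yl or a simple methyl on this nitrogen would help separate these.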